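A few compounds are considered here, and "the series" means these few. Any claim that something is new, unique, unknown or untested is made for them only; others in the source may bear on it.

Measured in an assay on membranes from CHO cells for displacement of a labelled ligand from adenosine receptor A1 (Homo sapiens), read by scintillation counting, with a stated time of 60 min, tested at 1 uM; a higher number here means more inhibition at the concentration tested (going by the name of the read-out), a lower number less inhibition:
compound 1, `CC1=C(C(=O)OCc2ccccc2)C(c2ccco2)NC(=O)N1`, gives 36%.
compound 2, `CCSC(=O)C1=C(C)NC(=O)NC1c1ccco1`, gives 6%.
compound 3, `CC1=C(C(=O)SC(C)C)C(c2ccco2)NC(=O)N1`, gives 5%.

Compound 3 has the lowest of the three numbers. Its nearest neighbour is compound 2, whose value lies within the scatter of it; the furthest is compound 1, whose value lies beyond the scatter above it. Within the data shown here, the one step that is fully characterised, a number 1 percentage points lower from compound 2 to compound 3 (within the scatter), stays within the scatter and concerns only the chain on the sulfur.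

Compound 4, `CC1=C(C(=O)OCC2CC2)C(c2ccco2)NC(=O)N1`, is not yet measured. It differs from compound 3 in one place: cyclopropylmethoxy in place of isopropylsulfanyl on a carbonyl carbon. Among the measured compounds shown here, no measured step of this kind exists. For the measured compounds named here, the only compound carrying an oxygen rather than a sulfur on that carbonyl carbon is compound 1, and its value stands above that of compound 3 beyond the scatter, though its group on the oxygen is a benzyl, not a cyclopropylmethyl. Because compound 1 gives 36%, a rise is expected, and the step is estimated as a number 17 percentage points higher from compound 3 to compound 4 (beyond the scatter). Compound 4 is therefore expected to give about 22%, within a range from 5% to 40%.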

Compound 4, a percentage reported as inhibition, at one concentration (the size of the read-out at that concentration, not a potency): 29%
The estimate for compound 4 lay 7 percentage points below the measured number; low and high end bracket the measured number.
By their numbers in this assay, from the lowest: compounds 3 and 2 (each within the scatter of the next); then compounds 4 and 1 (each within the scatter of the next).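

In this assay, replacing isopropylsulfanyl with cyclopropylmethoxy on the carbonyl carbon gives a number 24 percentage points higher from compound 3 to compound 4 (beyond the scatter), and replacing ethylsulfanyl with the same group gives a number 23 percentage points higher from compound 2 to compound 4 (beyond the scatter), so this position can respond to a change of group far more than the change in the chain on the sulfur showed, and an oxygen-linked group other than benzyl also reaches a higher number than both sulfur-linked compounds. Cyclopropyl in place of phenyl on the saturated chain carbon bound to an oxygen next to a carbonyl group gives a number 7 percentage points lower from compound 1 to compound 4 (within the scatter), so the cyclopropylmethoxy and benzyl-bearing compounds cannot be told apart in this assay. Nothing available accounts for these steps.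

Because the step from compound 3 changes the linking atom and the chain together, the compounds shown leave open how much of it belongs to the oxygen and how much to the cyclopropylmethyl group, which an isopropoxy or ethoxy group on the same carbonyl carbon would separate. They also leave open whether an amine-linked group, such as ethylamino, or a longer chain on the oxygen would hold or change the number.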